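A few compounds are considered here, and "the series" means these few. Any claim that something is new, unique, unknown or untested is made for them only; others in the source may bear on it.

Working notes on the series. Three compounds sharing one core have been run in a functional assay on cells for antagonist activity at prostaglandin D2 receptor 2 (Homo sapiens), read by flow cytometry, with a stated time of 10 min; on this read-out higher numbers stand for weaker inhibition and lower numbers for stronger inhibition. Compound 1 `CCCS(=O)(=O)c1cccc(C#Cc2cc(Cl)ccc2OCC(=O)O)c1` gives 750 nM. Compound 2 `CN(C)S(=O)(=O)c1cncc(C#Cc2cc(Cl)ccc2OCC(=O)O)c1` gives 289 nM. Compound 3 `CC(C)c1ccc(S(C)(=O)=O)cc1C#Cc1cc(Cl)ccc1OCC(=O)O` gives 360 nM. Of these three numbers, that of compound 3 is the second highest; it lies within the scatter of the number of compound 2, so nothing separates those two, while compound 1 gives a number beyond the scatter above that of compound 3, so compound 1 inhibits more weakly than compound 3 in this assay.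

The next compound is compound 4 `Cc1ccc(S(C)(=O)=O)cc1C#Cc1cc(Cl)ccc1OCC(=O)O`. The change from compound 3 is methyl in place of isopropyl on an aromatic carbon. For the measured compounds named here, no measured pair in the set differs in just this one place, so there is no comparable step to go by. Replacing the isopropyl with a methyl is a modest change, and the expectation is a step of a 1.1-fold higher number from compound 3 to compound 4 (0.05 log units; within the scatter) that stays within the scatter, with no firm direction. Compound 4 is therefore estimated at 400 nM in this assay, with a range from 180 nM to 900 nM.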

Compound 4, half-maximal inhibitory concentration: 64 nM
Beside the measured number, compound 4's estimate is 6.3-fold (0.80 log units) above it, and the stated range ends above it.
By their numbers in this assay, from the lowest: compound 4; then compounds 2 and 3 (each within the scatter of the next); then compound 1.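

In this assay, methyl in place of isopropyl on this aromatic carbon, para to a methylsulfonyl group, gives a 5.6-fold lower number from compound 3 to compound 4 (0.75 log units; beyond the scatter) and so shows that the choice of alkyl group at this position matters. For the compounds shown here, the earlier compounds included no pair differing in one place, which makes this the first step that can be read on its own. Nothing measured in the series accounts for this step.

From the compounds shown here alone, it remains open whether an ethyl group would give a number closer to that of compound 3 or compound 4, and how a hydrogen, a chlorine or a methoxy group would compare with the methyl of compound 4. Going by these compounds, it is also open whether the same exchange would give a similar step with other groups in place of the methylsulfonyl group.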